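The compounds below may be only part of what the source reports. "The series", "measured", "known", "first", "only" and "open" are said of these compounds alone.

In a functional assay on MCF7 cells (Homo sapiens) for inhibition, with a stated time of 48 h, tested at 50 uM (a lower number here means less inhibition of growth, a higher number more inhibition of growth at the concentration tested), compound 1 (`C=C[C@@](C)(/C=C/c1ccc(OC(=O)CC)cc1)CCC=C(C)C`) gives 23%, compound 2 (`C=C[C@@](C)(/C=C/c1ccc(OC(=O)CCCC)cc1)CCC=C(C)C`) gives 25% and compound 3 (`C=C[C@@](C)(/C=C/c1ccc(OC(=O)CCCCCCC)cc1)CCC=C(C)C`) gives 12%, the lowest of the three. The next change, to compound 4 (`C=C[C@@](C)(/C=C/c1ccc(OC)cc1)CCC=C(C)C`), is methyl in place of heptylcarbonyl on an oxygen on an aromatic ring. The measured steps only vary the saturated chain: a number 2 percentage points higher from compound 1 to compound 2 (within the scatter), then a number 11 percentage points lower from compound 1 to compound 3 (beyond the scatter) and a number 13 percentage points lower from compound 2 to compound 3 (beyond the scatter). None of them removes the carbonyl, so they bear on this change only loosely. The expected step is a number 8 percentage points higher from compound 3 to compound 4 (within the scatter), so no clear shift in this assay is expected. The estimate for compound 4 is 20%, with an expected range of 5% to 40%.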

Compound 4, percent growth inhibition at one concentration: 18%
The estimate for compound 4 lay 2 percentage points above the measured number, within the range that was stated.
By their numbers in this assay, from the lowest: compounds 3, 4, 1 and 2 (each within the scatter of the next, the first and the last beyond it).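

In this assay methyl on the oxygen on an aromatic ring gives a number 6 percentage points higher from compound 3 to compound 4 (within the scatter) and a number 7 percentage points lower from compound 2 to compound 4 (within the scatter) and also a number 5 percentage points lower from compound 1 to compound 4 (within the scatter) at this position. Loss of the carbonyl therefore leaves compound 4 within the scatter of all three esters, although compound 2 and compound 3 stand apart beyond it. No supporting data bear on why this is so.

Still open, as far as these compounds go, is whether a free hydroxyl on this oxygen, or an amine or carboxylic acid at the end of the chain, would shift growth inhibition beyond the scatter.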